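The source may report more compounds than this note shows. Statements on the series, on what has been measured and on what is new or still open speak of the compounds shown alone.

Of the compounds shown here, three of a shared core have been measured in a functional assay (trachea) with Rattus norvegicus as the target; a lower number here means a less potent compound, a higher number a more potent compound, by a factor of ten per unit of this negative logarithm. Compound 1 `COc1ccc2c(c1)C(n1ccccc1=O)=CC(C)(C)O2` gives 5.99. Compound 2 `CC1(C)C=C(n2ccccc2=O)c2cc(C(=O)c3ccco3)ccc2O1` gives 5.92, and compound 3 `Cc1ccccc1C(=O)c1ccc2c(c1)C(n1ccccc1=O)=CC(C)(C)O2` gives 6.25. The step of a number 0.07 log units lower from compound 1 to compound 2 (within the scatter) leaves compound 2 and compound 1 on a par, while the step of a number 0.33 log units higher from compound 2 to compound 3 (beyond the scatter) sets compound 2 apart from compound 3, so compound 2 stands at the low side of the three, though separated clearly only from compound 3.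

The next compound is compound 4 `CC1(C)C=C(n2ccccc2=O)c2cc(C(=O)c3c(F)cccc3F)ccc2O1`, which differs from compound 2 in one place: 2,6-difluorophenyl in place of furan-2-yl on a carbonyl carbon. For the measured compounds named here, one measured step bears directly on this change, a number 0.33 log units higher from compound 2 to compound 3 (beyond the scatter), in which the furan-2-yl on the carbonyl carbon was also exchanged for a six-membered carbon-only ring, with a modest rise. The step of a number 0.26 log units higher from compound 1 to compound 3 (within the scatter) points the same way without leaving the scatter. Going by the values given here, the exchange here brings a ring of the same kind, though carrying two fluorines, and no measured pair shows the effect of those fluorines.

A step of a number 0.33 log units higher from compound 2 to compound 4 (beyond the scatter) is therefore expected in this assay, in the upward direction, roughly matching what compound 3 showed. The expected value for compound 4 is 6.25, with a range from 5.85 to 6.65.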

Compound 4, logarithm of the reciprocal of the active concentration, log(1/C): 5.99
Beside the measured number, compound 4's estimate is 0.26 log units above it; the measured number falls inside the stated range.
By their numbers in this assay, from the lowest: compounds 2, 1, 4 and 3 (each within the scatter of the next, the first and the last beyond it).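

In this assay, the step of a number 0.07 log units higher from compound 2 to compound 4 (within the scatter) shows that a six-membered carbon-only ring on this carbonyl carbon does not by itself set a compound apart from the furan-2-yl compound, so the ring type alone does not account for the earlier separation. The step of a number 0.26 log units lower from compound 3 to compound 4 (within the scatter) also leaves compound 4 on a par with the 2-methylphenyl compound, which means that compound 4 bridges the two compounds separated by the step of a number 0.33 log units higher from compound 2 to compound 3 (beyond the scatter) without showing which of them it resembles more. Nothing available here offers an explanation for this outcome.

With steps this small, the compounds shown leave open whether the two fluorines and the single methyl matter at all, and an unsubstituted phenyl on the carbonyl carbon would be the direct reference for that question. They also leave open how this position would respond to a group of a different kind, such as a pyridine ring, an open alkyl chain or an amine, in place of the aromatic rings seen so far.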